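This account rests on a few compounds, and the source may have more. Where it says the series, first, only, none or still open, it means among the compounds named here.

Measured in an assay on CHO-K1 cells for displacement of a labelled ligand from prostaglandin E2 receptor EP1 subtype (Homo sapiens); on this read-out lower numbers stand for stronger inhibition and higher numbers for weaker inhibition:
compound 1 `Cc1cc(C(=O)NCc2ccncc2)nn1Cc1cc(Cl)ccc1OCc1ccccc1` gives 79.4 nM
compound 2 `Cc1cc(NC(=O)CC2CCCCC2)nn1Cc1cc(Cl)ccc1OCc1ccccc1` gives 6.31 nM

Among the measured compounds shown here, compound 2 holds the lowest number of the two; its only neighbour is compound 1, reached by a 13-fold lower number from compound 1 to compound 2 (1.10 log units; beyond the scatter), a large step. Compound 3 `Cc1cc(NC(=O)OCC(C)C)nn1Cc1cc(Cl)ccc1OCc1ccccc1` differs from compound 2 by isobutoxy in place of cyclohexylmethyl on a carbonyl carbon. For the measured compounds named here, no measured step alters a group on the carbonyl carbon while the amino-linked carbonyl arrangement stays, so the one step measured bears only indirectly, showing that this arrangement with cyclohexylmethyl gave the lowest number. The expected step is a 2.5-fold higher number from compound 2 to compound 3 (0.40 log units; beyond the scatter), a modest rise beyond the scatter. Compound 3 is estimated at 16 nM, range 5 nM to 60 nM.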

Compound 3, half-maximal inhibitory concentration: 25.1 nM
For compound 3 the middle estimate is 1.6-fold (0.20 log units) below the measured one; measured number inside the range.
By their numbers in this assay, from the lowest: compound 2; then compound 3; then compound 1.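

On the carbonyl carbon whose other neighbour is the amide-type nitrogen, this assay shows that the group there can be changed with a measurable cost: isobutoxy in place of cyclohexylmethyl gives a 4.0-fold higher number from compound 2 to compound 3 (0.60 log units; beyond the scatter) and so costs less than the earlier carbamoyl-to-amino step gained. The six-membered ring is therefore not essential to beating compound 1, as a 3.2-fold lower number from compound 1 to compound 3 (0.50 log units; beyond the scatter) shows for the ringless isobutoxy group. No supporting measurement accounts for either step.

From the compounds shown here alone, whether the rise follows the lost ring or the entering oxygen remains open. Cyclohexylmethoxy or a plain isobutyl group on the same carbonyl carbon would separate the two, and an amine there would test a further linkage.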